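Trimethoxyphenyl Gives Way to Fluorophenyl: Compound 3 Anticipated

The source may hold more compounds than are shown below. What is called first, only, known or untested is meant among the compounds shown, and "the series" means these compounds.

Compound 1, `COc1ccc(C2=NOC(COc3ccc(-c4nnnn4-c4cc(OC)c(OC)c(OC)c4)cc3N)C2)cc1OC`: in a functional assay on A549 cells (Homo sapiens) for cytotoxicity, read by MTT assay, with a stated time of 48 h (a lower number here means a stronger inhibitor, a higher number a weaker inhibitor), compound 1 gives 2520 nM.
Compound 2, `COc1cc(C2=NOC(COc3ccc(-c4nnnn4-c4cc(OC)c(OC)c(OC)c4)cc3N)C2)cc(OC)c1OC`: in this assay compound 2 gives 2060 nM.

For the measured compounds named here, compound 2 holds the lowest of the two numbers, with compound 1 nearest; the only measured step is a 1.2-fold lower number from compound 1 to compound 2 (0.09 log units; within the scatter). Compound 3, `COc1cc(-n2nnnc2-c2ccc(OCC3CC(c4ccccc4F)=NO3)c(N)c2)cc(OC)c1OC`, differs from compound 2 in one place: 2-fluorophenyl in place of 3,4,5-trimethoxyphenyl on a carbon with a double bond to nitrogen. That single step swapped a methoxy for hydrogen on the same ring and stayed within the scatter, so it bears only loosely on removing the whole 3,4,5-trimethoxyphenyl. Near compound 2, perhaps a little weaker, is where compound 3 is expected: a 1.6-fold higher number from compound 2 to compound 3 (0.19 log units; within the scatter). The number expected for compound 3 in this assay is 3200 nM, with a range from 1200 nM to 9000 nM.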

Compound 3, half-maximal inhibitory concentration: 1490 nM
Beside the measured number, compound 3's estimate is 2.1-fold (0.33 log units) above it, within the range that was stated.
By their numbers in this assay, from the lowest: compounds 3, 2 and 1 (each within the scatter of the next).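

In this assay, 2-fluorophenyl in place of 3,4,5-trimethoxyphenyl gives a 1.4-fold lower number from compound 2 to compound 3 (0.14 log units; within the scatter) and in place of 3,4-dimethoxyphenyl gives a 1.7-fold lower number from compound 1 to compound 3 (0.23 log units; within the scatter) at this carbon with a double bond to nitrogen. Both steps stay within the scatter, so across these compounds the methoxy groups on this ring can all go, and the number holds with a ring carrying 0 hydrogen-bond acceptors. Nothing available accounts for this result. Going by these compounds, whether a plain phenyl, a pyridine ring or an aminophenyl here would move the number beyond the scatter stays open.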